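Aryl sulfonyl variation on the shared core

The source may report more compounds than this note shows. Statements on the series, on what has been measured and on what is new or still open speak of the compounds shown alone.

Compound 1 `CC1CCN(C2CCN(S(=O)(=O)c3ccc(C#N)cc3)CC2)CC1` carries a 4-cyanophenyl on the sulfonyl sulfur; in a functional assay on DLD-1 cells (Homo sapiens) for antiproliferative activity, read by CellTiter-Glo, with a stated time of 72 h (a lower number here means a stronger inhibitor, a higher number a weaker inhibitor), compound 1 gives 2800 nM, the highest number among the three measured compounds. Compound 2 `CC1CCN(C2CCN(S(=O)(=O)c3cccc(Br)c3)CC2)CC1` gives 3.2 nM and compound 3 `CC1CCN(C2CCN(S(=O)(=O)c3ccc(Cl)c(Cl)c3)CC2)CC1` gives 2.9 nM; these two lie within the scatter of each other (a 1.1-fold lower number from compound 2 to compound 3 (0.04 log units; within the scatter)). The two measured steps away from the 4-cyanophenyl are both large: an 880-fold lower number from compound 1 to compound 2 (2.94 log units; beyond the scatter) and a 970-fold lower number from compound 1 to compound 3 (2.98 log units; beyond the scatter). Compound 4 `COc1ccc(-c2ccc(S(=O)(=O)N3CCC(N4CCC(C)CC4)CC3)cc2)cc1` differs from compound 1 by 4-methoxyphenyl in place of cyano on an aromatic carbon. Among the compounds with values here, no measured step replaces the cyano with an aromatic group, so those two steps bear only indirectly; they show that leaving the 4-cyanophenyl has so far given a much lower number. The expected step is therefore estimated as a 47-fold lower number from compound 1 to compound 4 (1.67 log units; beyond the scatter), though its size is uncertain. The estimate for compound 4 is 60 nM, with a range from 5 nM to 900 nM.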

Compound 4, half-maximal inhibitory concentration: 263 nM
For compound 4 the middle estimate is 4.4-fold (0.64 log units) below the measured one, and the stated range covers the measured number.
By their numbers in this assay, from the lowest: compounds 3 and 2 (each within the scatter of the next); then compound 4; then compound 1.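

At this aromatic carbon, a 4-methoxyphenyl in place of cyano gives an 11-fold lower number from compound 1 to compound 4 (1.03 log units; beyond the scatter) in this assay. Within the data shown here, this is the first measured change made directly at the cyano, and it shows that a lower number can be reached while the sulfonyl-bearing phenyl ring is kept and a large aromatic group is added para to it. Nothing measured explains the size of this step.

On these data alone, a plain phenyl or an amine at this carbon remains open. So does the effect of moving the 4-methoxyphenyl to another ring carbon.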